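A few compounds are considered here, and "the series" means these few. Any claim that something is new, unique, unknown or untested is made for them only; others in the source may bear on it.

Measured in a functional assay on NCI-H661 cells (Homo sapiens) for inhibition, read by MTT assay, with a stated time of 72 h; a lower number here means a stronger inhibitor, a higher number a weaker inhibitor:

Compound 1 `Nc1ccccc1NC(=O)c1ccc(CNCc2nc(-c3ccc(Cl)cc3)no2)cc1` gives 8000 nM
Compound 2 `O=C(NO)c1ccc(CNCc2nc(-c3ccccc3)no2)cc1` gives > 100000 nM

Compound 2 stands only at a limit of the assay, > 100000 nM, and not at a number. Compound 3 `O=C(NO)c1ccc(CNCc2nc(-c3ccc(Cl)cc3)no2)cc1` differs from compound 2 by chloro in place of hydrogen on an aromatic carbon. Among the measured compounds shown here, no measured pair shows this change in this assay. Compound 1 also carries 4-chlorophenyl and gives 8000 nM, so a modest move towards a lower number is expected. The estimated step is an at least 2.0-fold lower number from compound 2 to compound 3 (0.30 log units; that floor lies within the scatter). For compound 3 the expected value is 50000 nM, with an estimated range of 10000 nM to 200000 nM.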

Compound 3, half-maximal inhibitory concentration: > 100000 nM
Compound 3 ended at the assay's limit (the forecaster's own chance of this, stated with the estimate: 45%); middle value at least 2.0-fold (0.30 log units) from the limit.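

Compound 3 also stands at a limit of this assay, so 4-chlorophenyl in place of phenyl does not bring this hydroxy amide to a number, and the step between compound 2 and compound 3 cannot be read. With 4-chlorophenyl held constant, hydroxy in place of 2-aminophenyl on an amide-type nitrogen gives an at least 12-fold higher number from compound 1 to compound 3 (1.09 log units; beyond the scatter), so the change on that nitrogen is the one that can be read: the limit of > 100000 nM in this assay, at which 2 of the 3 values shown sit.

As far as these compounds go, whether a plain phenyl or a pyridine on that nitrogen would give a number in this assay stays open. So does whether chloro shifts the value when 2-aminophenyl sits there.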